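A pyridin-3-yl exchange on compound 2

The compounds below may be only part of what the source reports. "The series", "measured", "known", "first", "only" and "open" are said of these compounds alone.

In an ADME assay on microsomes from liver (Mus musculus) for metabolic stability, read by LC-MS, using NADPH, tested at 4.6 uM (a higher number here means that the compound lasts longer, a lower number that the compound disappears faster), compound 1 (`CC(C)CNC(=O)n1cc(-c2ccccc2)oc1=O`) gives 0.833 h, and compound 2 (`O=C(NCCCCc1ccccc1)n1cc(-c2ccc(F)cc2)oc1=O`) gives 1 h. These two values lie within the scatter of each other, so compound 2 stands level with compound 1 on the numbers available. Compound 3 (`O=C(NCCCCc1ccccc1)n1cc(-c2cccnc2)oc1=O`) has pyridin-3-yl in place of 4-fluorophenyl on an aromatic carbon, next to the ring oxygen of the shared core: pyridin-3-yl in place of 4-fluorophenyl on an aromatic carbon. For the measured compounds named here, no measured pair differs in one place only, so the data give no direct guide to this exchange. In this assay only a small downward step is expected, one that stays within the scatter. The expected step is a 1.3-fold lower number from compound 2 to compound 3 (0.10 log units; within the scatter). For compound 3 the estimated half-life is 0.8 h, with an expected range from 0.35 h to 1.8 h.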

Compound 3, half-life: > 1 h
Compound 3 ended at the assay's limit; the forecaster's own chance of this, stated with the estimate: 5%; middle value at least 1.2-fold (0.09 log units) away from the limit.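

The earlier compounds shown here carried only aromatic rings of carbon at this position, next to the ring oxygen; compound 3 brings a ring with a hetero atom there. In this assay compound 3 gives > 1 h, which is a limit of the assay and not a number. Pyridin-3-yl in place of 4-fluorophenyl therefore costs nothing measurable in half-life, as the step shows, with a number no lower from compound 2 to compound 3 (the limit leaves the size open), but how large the step is cannot be read: the limit of > 1 h in this assay, at which 1 of the 3 values shown sits.

From the compounds shown here alone, how far compound 3 lies past this limit remains open, so the exchange cannot be ranked by size. Also open, going by these compounds, is whether pyridin-4-yl, or a phenyl ring bearing an amine, would hold up in the same way on this aromatic carbon.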